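The source may hold more compounds than are shown below. What is called first, only, known or untested is meant among the compounds shown, and "the series" means these compounds.

Working notes on the series. In an ADME assay on NCI-H460 cells (Homo sapiens) for cytotoxicity, read by MTT assay, with a stated time of 72 h (a lower number here means a stronger inhibitor of growth, a higher number a weaker inhibitor of growth), compound 1 (`CCCCCCCCCCNC(=O)C1C(C(=O)O)[C@@H]2CC[C@H]1O2`) gives 10000 nM. Compound 2 (`C=CCNC(=O)C1C(C(=O)O)[C@@H]2CC[C@H]1O2`) gives 10000 nM, level with compound 1 at the digits reported and within the scatter. Within the data shown here, neither compound separates from the other on these numbers, and no step between measured compounds is available to calibrate the next change.

Compound 3 (`CCCCNC(=O)C1C(C(=O)O)[C@@H]2CC[C@H]1O2`) keeps the shared core of compound 2 and differs in one place: propyl in place of vinyl on a saturated chain carbon bound to an amide-type nitrogen. Cut one bond further out, the same difference reads allyl to butyl.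

The expectation rests only on two values: compound 1 at 10000 nM and compound 2 at 10000 nM. These two compounds carry different groups on the amide nitrogen, yet their values are level. The estimated step of no change at the digits printed from compound 2 to compound 3 (within the scatter) is therefore expected to stay within the scatter, with no direction favoured in this assay. For compound 3 the estimated value is 10000 nM, with an expected range of 4000 nM to 20000 nM.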

Compound 3, concentration for 50% growth inhibition: 10000 nM
Beside the measured number, compound 3's estimate shows no gap at the digits printed; low and high end bracket the measured number.
By their numbers in this assay, from the lowest: compounds 1, 2 and 3 (each within the scatter of the next).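

The step in this assay reads no change at the digits printed from compound 2 to compound 3 (within the scatter), so at this place, on a saturated chain carbon bound to an amide-type nitrogen, exchanging vinyl for propyl does not separate the two compounds, even though the double bond outside aromatic rings leaves with the vinyl. A second reading now comes from the same chain: no change at the digits printed from compound 1 to compound 3 (within the scatter), with hydrogen in place of hexyl on a saturated chain carbon, four bonds along the chain from an amide-type nitrogen, so a change of this size further out on the chain also leaves the reading where it was. No measurement at hand accounts for these readings.

From the compounds shown here alone, whether an amine or a phenyl ring on the chain would move the reading away from this level stays open. Also open, going by these compounds, is whether a methyl ester in place of the carboxylic acid on the shared core would give a reading that differs from those of this set.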